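Swapping a Nitrophenyl for a Dimethoxyphenyl Group

The source may hold more compounds than are shown below. What is called first, only, known or untested is meant among the compounds shown, and "the series" means these compounds.

Compound 1 `COc1cc2ncnc(Nc3ccc(F)c(Cl)c3)c2cc1NC(=O)/C=C/c1ccc(F)cc1Cl`: "not active" (no number reported)
Compound 2 `COc1ccc(/C=C/C(=O)Nc2cc3c(Nc4ccc(F)c(Cl)c4)ncnc3cc2O[C@H]2CCOC2)c(OC)c1`: 9350 nM
Compound 3 `COc1cc2ncnc(Nc3ccc(F)c(Cl)c3)c2cc1NC(=O)/C=C/c1ccccc1[N+](=O)[O-]`: 33300 nM

These results come from a functional assay on A549 cells (Homo sapiens) for cytotoxicity, read by MTT assay, with a stated time of 72 h; on this read-out lower numbers stand for stronger inhibition and higher numbers for weaker inhibition. Within the data shown here, compound 1 was reported without a number, so only two values can be compared directly. Of those two, compound 3 has the higher number and therefore the weaker inhibition, and its gap to compound 2 lies beyond the usual scatter.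

Compound 4 `COc1ccc(/C=C/C(=O)Nc2cc3c(Nc4ccc(F)c(Cl)c4)ncnc3cc2OC)c(OC)c1` has not yet been measured in this assay. Relative to compound 3, it carries a 2,4-dimethoxyphenyl group in place of 2-nitrophenyl, on a double-bonded chain carbon bound to a double-bonded chain carbon: 2,4-dimethoxyphenyl in place of 2-nitrophenyl on a double-bonded chain carbon bound to a double-bonded chain carbon.

The best guide is compound 2 at 9350 nM, which carries the same 2,4-dimethoxyphenyl group, although it differs from compound 4 elsewhere in its structure. A moderate move toward stronger inhibition is therefore expected, with an estimated 2.6-fold lower number from compound 3 to compound 4 (0.41 log units; beyond the scatter). For compound 4 the estimated value is 13000 nM, with an expected range from 4000 nM to 40000 nM.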

Compound 4, half-maximal inhibitory concentration: 33300 nM
Beside the measured number, compound 4's estimate is 2.6-fold (0.41 log units) below it, within the range that was stated.
By their numbers in this assay, from the lowest: compound 2; then compounds 3 and 4 (each within the scatter of the next).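

In this assay, among these compounds, the exchange of 2-nitrophenyl for 2,4-dimethoxyphenyl on a double-bonded chain carbon bound to a double-bonded chain carbon gives no change at the digits printed from compound 3 to compound 4 (within the scatter) and is the first one-place reading at this position, so the two groups cannot be told apart here. The new compound also opens a second comparison: with 2,4-dimethoxyphenyl held the same, methyl in place of oxolan-3-yl on an oxygen on an aromatic ring gives a 3.6-fold higher number from compound 2 to compound 4 (0.55 log units; beyond the scatter) and this modest step shows that the group on that oxygen can shift the number even where the aryl exchange did not. No measurement available here explains either result.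

On these data alone, whether oxolan-3-yl would bring the same step to the 2-nitrophenyl compound remains open. So does the effect of an amine, such as a morpholine, in place of oxolan-3-yl on that oxygen.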